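Aryl variation on the sulfonyl of the piperidinyl-piperidine core

The compounds below may be only part of what the source reports. "The series", "measured", "known", "first", "only" and "open" are said of these compounds alone.

Measured compounds:
compound 1 `CC1CCN(C2CCN(S(=O)(=O)c3cccc(N)c3)CC2)CC1` — 3400 nM
compound 2 `CC1CCN(C2CCN(S(=O)(=O)c3cnc(Cl)s3)CC2)CC1` — 1800 nM
compound 3 `CC1CCN(C2CCN(S(=O)(=O)c3cccnc3F)CC2)CC1` — > 5000 nM

In a functional assay on DLD-1 cells (Homo sapiens) for antiproliferative activity, read by CellTiter-Glo, with a stated time of 72 h (a higher number here means a weaker inhibitor, a lower number a stronger inhibitor), compound 1 gives the higher of the two numbers reported, and the step of a 1.9-fold lower number from compound 1 to compound 2 (0.28 log units; within the scatter) is small. For compound 3 this assay reports only a limit, (the limit of > 5000 nM in this assay, at which 1 of the 3 values shown sits). Compound 4 `CC1CCN(C2CCN(S(=O)(=O)c3cccc(-c4ccc(F)cc4)c3)CC2)CC1` carries 4-fluorophenyl in place of amino on an aromatic carbon. For the measured compounds named here, no measured step swaps an amino group for an aryl ring, so the nearest guides are the aryl exchanges on the sulfonyl sulfur, an at least 1.4-fold higher number from compound 1 to compound 3 (0.16 log units; that floor lies within the scatter) and an at least 2.7-fold higher number from compound 2 to compound 3 (0.44 log units; beyond the scatter), which move this assay by at most modest amounts. A step of comparable size, without a firm direction, is therefore expected for compound 4. Compound 4 is estimated at 2500 nM (range 700 nM to 9000 nM), that is a 1.4-fold lower number from compound 1 to compound 4 (0.13 log units; within the scatter).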

Compound 4, half-maximal inhibitory concentration: 12 nM
The estimate for compound 4 lay 210-fold (2.32 log units) above the measured number; measured number outside the range, below it.
By their numbers in this assay, from the lowest: compound 4; then compounds 2 and 1 (each within the scatter of the next). At a limit, above all of these: compound 3.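

In this assay, 4-fluorophenyl in place of amino on an aromatic carbon, meta to a large group, gives a 280-fold lower number from compound 1 to compound 4 (2.45 log units; beyond the scatter). For the compounds shown here, no step among compounds 1, 2 and 3 shows a move of this size, although the steps to compound 3 rest on a limit. Nothing measured here bears on the cause of this change.

Open, on these data alone, is whether the change depends on the added ring, its fluorine or the loss of amino; an unsubstituted phenyl or a longer alkyl chain on that carbon would help separate these. Also open, as far as these compounds go, is whether 4-fluorophenyl would have a similar effect on the 2-chloro-1,3-thiazol-5-yl group of compound 2.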